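Notes on the chain substituent: compound 3 to compound 4

A few compounds are considered here, and "the series" means these few. Any claim that something is new, unique, unknown or untested is made for them only; others in the source may bear on it.

Values in a functional assay on the whole organism with Rattus norvegicus as the target; on this read-out lower numbers stand for an effect already at smaller amounts and higher numbers for an effect only at larger amounts of compound
compound 1 `CCCCn1c(=N)sc2cc(OC(F)(F)F)ccc21` (10 mg/kg)
compound 2 `N=c1sc2cc(OC(F)(F)F)ccc2n1Cc1ccccc1` (limit only) (> 10 mg/kg)
compound 3 `CCN(CC)C(=O)Cn1c(=N)sc2cc(OC(F)(F)F)ccc21` (9 mg/kg)

Within the data shown here, compound 3 (9 mg/kg) stands level with the only other number, and the step of a 1.1-fold lower number from compound 1 to compound 3 (0.05 log units; within the scatter) gives no ranking. The value for compound 2 (> 10 mg/kg) is a limit. The step of a number no lower from compound 1 to compound 2 (the limit leaves the size open) therefore has no readable size, and the step of an at least 1.1-fold lower number from compound 2 to compound 3 (0.04 log units; that floor lies within the scatter) has only a floor.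

Compound 4 `CNS(=O)(=O)CCn1c(=N)sc2cc(OC(F)(F)F)ccc21` carries (methylsulfamoyl)methyl in place of diethylcarbamoyl on a saturated chain carbon bound to an aromatic nitrogen and has no value yet. Among the measured compounds shown here, the only fully readable step at this place is a 1.1-fold lower number from compound 1 to compound 3 (0.05 log units; within the scatter) and it stays within the scatter, so no step beyond the scatter is expected in this assay in either direction. The expected size is a 1.1-fold higher number from compound 3 to compound 4 (0.05 log units; within the scatter) in this estimate. A report of only a limit, as in the limit of > 10 mg/kg in this assay, at which 1 of the 3 values shown sits, also remains possible. The estimate for compound 4 is 10 mg/kg with an expected range of 4 mg/kg to 25 mg/kg as the likely span.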

Compound 4, dose for half-maximal effect: 4 mg/kg
For compound 4 the middle estimate is 2.5-fold (0.40 log units) above the measured one, and the stated range covers the measured number.
By their numbers in this assay, from the lowest: compound 4; then compounds 3 and 1 (each within the scatter of the next).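

In this assay, among these compounds, the chain substituent now moves the number beyond the scatter, with a 2.3-fold lower number from compound 3 to compound 4 (0.35 log units; beyond the scatter) and a 2.5-fold lower number from compound 1 to compound 4 (0.40 log units; beyond the scatter), whereas the fully readable step among the earlier compounds stayed within it. The step of an at least 2.5-fold lower number from compound 2 to compound 4 (0.39 log units; beyond the scatter) gives only a floor, although that floor already lies beyond the scatter. Compound 2 stands at a limit: the limit of > 10 mg/kg in this assay, at which 1 of the 4 values shown sits.

As far as these compounds go, it remains open which part of the (methylsulfamoyl)methyl group carries the step, the methylsulfamoyl end or the methyl link that joins it to the chain. From the compounds shown here alone, it is also open whether the lower number is particular to this group, and a dimethylsulfamoyl group, a carboxylic acid or an amine on the same chain would help to separate these readings.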